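Chloro for methyl on a fluorocinnamoyl amide series

The compounds below may be only part of what the source reports. "The series", "measured", "known", "first", "only" and "open" are said of these compounds alone.

Compound 1 `COc1ccc(-c2nnc(NC(=O)/C=C/c3ccc(F)cc3)s2)cc1` gives 0.75 ug/mL
Compound 2 `Cc1ccc(-c2nnc(NC(=O)/C=C/c3ccc(F)cc3)s2)cc1` gives 1.23 ug/mL
Compound 3 `O=C(/C=C/c1ccc(F)cc1)Nc1nnc(-c2ccc(Cl)cc2)s1` is not yet measured

Within the data shown here, in a functional assay on A549 cells (Homo sapiens) for antiproliferative activity, read by MTT assay, with a stated time of 48 h (on this read-out higher numbers stand for weaker inhibition and lower numbers for stronger inhibition), compound 2 stands within the scatter of compound 1, the only other number available. Compound 3 carries chloro in place of methyl on an aromatic carbon, para to a large group (chloro in place of methyl on an aromatic carbon). Among the measured compounds shown here, the only measured step at that place, methyl in place of methoxy (a 1.6-fold higher number from compound 1 to compound 2 (0.21 log units; within the scatter)), stays within the scatter. For the measured compounds named here, no measured step covers chloro, so the forecast is weakly founded, and no shift beyond the scatter in either direction is expected. The expected step is small (a 1.2-fold lower number from compound 2 to compound 3 (0.09 log units; within the scatter)). For this assay compound 3 is estimated at 1 ug/mL with an expected range from 0.4 ug/mL to 2.5 ug/mL around that figure.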

Compound 3, half-maximal inhibitory concentration: 2.06 ug/mL
The estimate for compound 3 lay 2.1-fold (0.31 log units) below the measured number; low and high end bracket the measured number.
By their numbers in this assay, from the lowest: compounds 1, 2 and 3 (each within the scatter of the next, the first and the last beyond it).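

In this assay, among these compounds, the step from methyl to chloro, para to a large group, stays within the scatter (a 1.7-fold higher number from compound 2 to compound 3 (0.22 log units; within the scatter)), whereas chloro in place of methoxy gives the first step beyond it at this position, though a modest one (a 2.7-fold higher number from compound 1 to compound 3 (0.44 log units; beyond the scatter)). Methoxy and chloro are therefore told apart here, while methyl is told apart from neither. Nothing measured here explains this gap. The compounds shown leave open how an amine or a hydroxyl group at this carbon would read, and whether the gap between methoxy and chloro persists when another group replaces the fluorine on the cinnamoyl part.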